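Methoxy in Place of Bromo in a HeLa Growth Assay

This account rests on a few compounds, and the source may have more. Where it says the series, first, only, none or still open, it means among the compounds named here.

Measured so far in a functional assay on HeLa cells (Homo sapiens) for inhibition, read by sulforhodamine B assay, with a stated time of 48 h; a lower number here means a stronger inhibitor of growth, a higher number a weaker inhibitor of growth:
- Compound 1, `COC(=O)[C@@]1(C)CC[C@@H]2C3=C1CC[C@@H](C)[C@]3(C)Cc1c2[nH]c2ccc(C)cc12`, gives 11000 nM
- Compound 2, `COC(=O)[C@@]1(C)CC[C@@H]2C3=C1CC[C@@H](C)[C@]3(C)Cc1c2[nH]c2ccc(Br)cc12`, gives 14000 nM

Both compounds share the same core and differ only in the group carried on the aromatic carbon of the six-membered ring. The change from the methyl group of compound 1 to the bromo group of compound 2 gave a 1.3-fold higher number from compound 1 to compound 2 (0.10 log units; within the scatter), so the two numbers lie within the usual scatter of each other and neither can be ranked above the other. Compound 2 stands at the higher of the two numbers, with compound 1 its nearest neighbour.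

Compound 3, `COC(=O)[C@@]1(C)CC[C@@H]2C3=C1CC[C@@H](C)[C@]3(C)Cc1c2[nH]c2ccc(OC)cc12`, takes the next step at the same position: methoxy in place of bromo on an aromatic carbon. Among the compounds with values here, none of the measured steps involves a methoxy group, so no step bears directly on this change; the only step available, from methyl to bromo, stayed within the scatter. On that basis compound 3 is expected to sit close to compound 2 in this assay, with a step of about a 1.2-fold lower number from compound 2 to compound 3 (0.07 log units; within the scatter), that is, no change beyond the scatter. The estimate for compound 3 is 12000 nM, with a range from 5000 nM to 30000 nM.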

Compound 3, concentration for 50% growth inhibition: 3900 nM
Beside the measured number, compound 3's estimate is 3.1-fold (0.49 log units) above it; the measured number lies below the stated range.
By their numbers in this assay, from the lowest: compound 3; then compounds 1 and 2 (each within the scatter of the next).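

This position, which looked indifferent while only methyl and bromo had been compared, responds to the group it carries: in this assay, methoxy in place of bromo gave a 3.6-fold lower number from compound 2 to compound 3 (0.56 log units; beyond the scatter), and methoxy in place of methyl gave a 2.8-fold lower number from compound 1 to compound 3 (0.45 log units; beyond the scatter). Both steps are modest, but both lie beyond the scatter, so compound 3 stands apart from compound 1 and compound 2, which remain within the scatter of each other. Nothing available accounts for the difference between the methoxy group and the other two groups at this aromatic carbon.

The compounds shown leave open whether this shift belongs to the methoxy group alone or would also appear with other groups on the same carbon, such as ethoxy, hydroxy or an amine. They also leave open whether the change from bromo to methoxy would have the same effect on another aromatic carbon of this ring, or on a core changed elsewhere, for instance one with a carboxylic acid in place of the methyl ester.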